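From methoxy to hydroxy on an aromatic ring

The source may hold more compounds than are shown below. What is called first, only, known or untested is meant among the compounds shown, and "the series" means these compounds.

Measured in a functional assay on HUVEC cells (Homo sapiens) for antiproliferative activity, read by MTT assay, with a stated time of 72 h; a lower number here means a stronger inhibitor, a higher number a weaker inhibitor:
- compound 1 `COCC1Oc2ccc(-c3oc4cc(O)cc(O)c4c(=O)c3OC)cc2OC1c1ccc(O)c(OC)c1`: 5400 nM
- compound 2 `COc1cc(C2Oc3cc(-c4oc5cc(O)cc(O)c5c(=O)c4O)ccc3OC2COC(=O)c2cc(O)c(O)c(O)c2)ccc1O`: 11300 nM
- compound 3 `COCC1Oc2ccc(-c3oc4cc(OC)cc(O)c4c(=O)c3O)cc2OC1c1ccc(O)c(OC)c1`: 4000 nM

In this assay, compound 3 cannot be told apart from compound 1, as their two values lie within the scatter of each other. Compound 3 is a stronger inhibitor than compound 2, and that gap lies beyond the scatter. Compound 4 `COCC1Oc2ccc(-c3oc4cc(O)cc(O)c4c(=O)c3O)cc2OC1c1ccc(O)c(OC)c1` carries hydrogen in place of methyl on an oxygen on an aromatic ring, so a methoxy becomes a hydroxy. Among the compounds with values here, no measured pair shows this change alone, so no step beyond the scatter is expected in this assay. The estimated step of a 1.3-fold higher number from compound 3 to compound 4 (0.10 log units; within the scatter) is small. The expected value for compound 4 is 5000 nM, within an estimated range of 2200 nM to 11000 nM.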

Compound 4, half-maximal inhibitory concentration: 5300 nM
Compound 4: middle estimate off by 1.1-fold (0.03 log units), on the low side; the measured number falls inside the stated range.
By their numbers in this assay, from the lowest: compounds 3, 4 and 1 (each within the scatter of the next); then compound 2.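

In this assay the change from methoxy to hydroxy reads the same at two different places on the core, with the step (a 1.3-fold higher number from compound 3 to compound 4 (0.12 log units; within the scatter)) and the step (a 1.0-fold lower number from compound 1 to compound 4 (0.01 log units; within the scatter)) both within the scatter. Exchanging (3,4,5-trihydroxyphenyl)carbonyl for methyl on an oxygen on a saturated carbon gives a modest step beyond the scatter (a 2.1-fold lower number from compound 2 to compound 4 (0.33 log units; beyond the scatter)). Nothing given here explains these steps.

Within the data shown here, whether hydroxy and methoxy are the only groups tolerated at these two places remains open. An ethoxy, a longer chain or an amine on that oxygen could still shift the number.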